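Notes on the step from compound 3 to compound 4

The source may report more compounds than this note shows. Statements on the series, on what has been measured and on what is new or still open speak of the compounds shown alone.

Measured so far in an assay on isolated protein for inhibition of polyamine deacetylase HDAC10 (Homo sapiens); on this read-out lower numbers stand for stronger inhibition and higher numbers for weaker inhibition:
compound 1 `O=C(NO)c1ccc(Cn2ccc3cc(C(=O)c4ccc(F)cc4)ccc32)cc1`: > 100000 nM, a limit of the assay, not a number
compound 2 `O=C(NO)c1ccc(Cn2ccc3cc(C(=O)c4ccc(Cl)cc4)ccc32)cc1`: > 100000 nM, again only a limit
compound 3 `Cc1ccc(C(=O)c2ccc3c(ccn3Cc3ccc(C(=O)NO)cc3)c2)cc1`: > 100000 nM, again only a limit

Compound 3 therefore stands at the limit alongside the other two (the limit of > 100000 nM in this assay, at which 3 of the 3 values shown sit), and the steps a step that the two limits leave unreadable from compound 1 to compound 2, a step that the two limits leave unreadable from compound 1 to compound 3 and a step that the two limits leave unreadable from compound 2 to compound 3 cannot be read from these values. Compound 4 `COc1cccc(C(=O)c2ccc3c(ccn3Cc3ccc(C(=O)NO)cc3)c2)c1` differs from compound 3 by 3-methoxyphenyl in place of 4-methylphenyl on a carbonyl carbon. Among the compounds with values here, none of the measured steps has a readable size to carry over, so the change is expected to leave this assay at or near the limit, a step that the limit leaves unreadable from compound 3 to compound 4. Compound 4 is estimated at 150000 nM, with a range from 40000 nM to 600000 nM.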

Compound 4, half-maximal inhibitory concentration: 47900 nM
Beside the measured number, compound 4's estimate is 3.1-fold (0.50 log units) above it; low and high end bracket the measured number.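

In this assay, within the data shown here, compound 4, with 3-methoxyphenyl on the carbonyl carbon, gives the first readable number, 47900 nM. The change gives an at least 2.0-fold lower number from compound 3 to compound 4 (0.31 log units; beyond the scatter), an at least 2.0-fold lower number from compound 2 to compound 4 (0.31 log units; beyond the scatter) and an at least 2.0-fold lower number from compound 1 to compound 4 (0.31 log units; beyond the scatter), so each size is only a minimum. The steps among compound 1, compound 2 and compound 3 cannot be read, and these three compounds remain at a limit, not a number: the limit of > 100000 nM in this assay, at which 3 of the 4 values shown sit.

The compounds shown leave open whether the methoxy group or its place on the phenyl ring carries the step. They also leave open how an amine or a carboxylic acid on that ring would read.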